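Two Assay Limits and a Methylindoline Successor

This account rests on a few compounds, and the source may have more. Where it says the series, first, only, none or still open, it means among the compounds named here.

Compound 1 `CS(=O)(=O)c1ccc(C(=O)N2CCC(C(=O)N3CCc4ccccc4C3)CC2)cc1[N+](=O)[O-]` reaches only a limit in an assay on isolated protein for inhibition of vitamin D3 receptor (Homo sapiens), read by fluorescence polarization; a higher number here means a weaker inhibitor, a lower number a stronger inhibitor: compound 1 gives > 60000 nM. Compound 2 `CN1CCN(C(=O)C2CCN(C(=O)c3ccc(S(C)(=O)=O)c([N+](=O)[O-])c3)CC2)CC1` also reaches only a limit in this assay: compound 2 gives > 60000 nM.

Compound 2 therefore stands at the limit of this assay, with no number of its own. Going by the values given here, the single step leading to it, a step that the two limits leave unreadable from compound 1 to compound 2, cannot be sized, since both ends are limits. Compound 3 `CC1Cc2ccccc2N1C(=O)C1CCN(C(=O)c2ccc(S(C)(=O)=O)c([N+](=O)[O-])c2)CC1` differs from compound 2 in one place: 2-methyl-2,3-dihydro-1H-indol-1-yl in place of 4-methylpiperazin-1-yl on a carbonyl carbon. Among the compounds with values here, only that unreadable step bears on this change, so no direction or size can be taken from it. Because the limit of > 60000 nM in this assay, at which 2 of the 2 values shown sit, shows every measured value sitting at the limit, compound 3 is expected to remain there as well. The step is estimated at a step that the limit leaves unreadable from compound 2 to compound 3. Compound 3 is thus estimated at 80000 nM, within 30000 nM to 250000 nM, most likely reported once more only as a limit.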

Compound 3, half-maximal inhibitory concentration: > 60000 nM
Compound 3 gave a limit, no number (the forecaster's own chance of this, stated with the estimate: 85%); the middle value lies beyond the limit too.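

In this assay, going by these compounds alone, compound 3 gives > 60000 nM, a limit and not a number, so no step among compound 1, compound 2 and compound 3 can be read. Left open is how strongly each compound inhibits the receptor, and whether changing the group on the carbonyl carbon alters that at all, given where the values stand: the limit of > 60000 nM in this assay, at which 3 of the 3 values shown sit.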